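The compounds below may be only part of what the source reports. "The series", "measured", "known", "first", "only" and "open" are said of these compounds alone.

Measured compounds:
compound 1, `CCCCN(CC)c1cc(C)nc2c1NC(=O)CN2c1ccc(C(C)(C)C)cc1Br` — -3.8%
compound 2, `CCCCN(CC)c1cc(C)nc2c1NC(=O)CN2c1ccc(C(C)C)cc1Br` — 0.7%
compound 3, `CCCCN(CC)c1cc(C)nc2c1NC(=O)CN2c1ccc(Cl)cc1Br` — "not determined" (no result reported)

In an assay on HEK-293T cells for displacement of a labelled ligand from corticotropin-releasing factor receptor 2 (Homo sapiens), read by scintillation counting, with a stated time of 2 h, tested at 1 uM (a higher number here means more inhibition at the concentration tested (going by the name of the read-out), a lower number less inhibition), compound 1 gives -3.8% and compound 2 gives 0.7%. Among the measured compounds shown here, the one measured step, a number 4.5 percentage points higher from compound 1 to compound 2 (within the scatter), shows that exchanging the group on the aryl ring of the shared core leaves the read-out essentially flat, with both compounds close to zero. Compound 3 carries a chloro group on that ring in place of the branched alkyl groups of compound 1 and compound 2, but in this assay compound 3 stands at "not determined" (no result reported), so where it sits relative to the other two is not known.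

Compound 4, `CCCCN(CC)c1cc(C)nc2c1NC(=O)CN2c1ccc(Cl)cc1Cl`, differs from compound 3 by chloro in place of bromo on an aromatic carbon. For the measured compounds named here, no measured step covers this exchange; the only step available, from compound 1 to compound 2, lies within the scatter and concerns a different position, so it gives no direction for this change. With both measured compounds near zero in this assay, compound 4 is expected to show little inhibition as well, estimated at 0% with a likely range from -10% to 12%.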

Compound 4, a percentage reported as inhibition, at one concentration (the size of the read-out at that concentration, not a potency): 0.9%
The estimate for compound 4 lay 0.9 percentage points below the measured number; the range from low to high includes it.
By their numbers in this assay, from the lowest: compounds 1, 2 and 4 (each within the scatter of the next).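

No new step can be read: in this assay compound 3 stands at "not determined" (no result reported), so compound 4 has no partner for comparison. The compounds shown leave open whether going from 2-bromo-4-chlorophenyl to 2,4-dichlorophenyl changes inhibition at all. No supporting evidence bears on this result.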